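This account rests on a few compounds, and the source may have more. Where it says the series, first, only, none or still open, it means among the compounds named here.

Measured so far in a functional assay on HEK293 cells for agonist activity at D(4) dopamine receptor (Homo sapiens), read by FLIPR; a higher number here means that more compound is needed for the effect, a lower number that less compound is needed:
compound 1 `Cc1cccc(NC(=O)CN2CCC(c3cccc(O)c3)CC2)c1` — 8 nM
compound 2 `Cc1cccc(NC(=O)CN2CCC(c3ccc(O)cn3)CC2)c1` — 3.8 nM

Compound 2 holds the lowest of the two numbers; its nearest neighbour is compound 1, and the step of a 2.1-fold lower number from compound 1 to compound 2 (0.32 log units; beyond the scatter) lies beyond the scatter. Compound 3 `COc1ccccc1C1CCN(CC(=O)Nc2cccc(C)c2)CC1` differs from compound 2 as follows: 2-methoxyphenyl in place of 5-hydroxypyridin-2-yl on a saturated ring carbon. Among the measured compounds shown here, the only measured step, a 2.1-fold lower number from compound 1 to compound 2 (0.32 log units; beyond the scatter), exchanges the aromatic ring while keeping a hydroxyl on it, so it speaks to the ring swap but not to the loss of the hydroxyl donor, and no measured pair covers a methoxy in this position. The change in compound 3 is therefore larger than anything yet tested, and the expectation rests on weak ground. A step away from the low number of compound 2 is expected, roughly a 7.9-fold higher number from compound 2 to compound 3 (0.90 log units; beyond the scatter), with wide uncertainty. For compound 3 the estimate is 30 nM, within 6 nM to 150 nM.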

Compound 3, half-maximal effective concentration: 420 nM
Compound 3: middle estimate off by 14-fold (1.15 log units), on the low side; the whole stated range lies below it.
By their numbers in this assay, from the lowest: compound 2; then compound 1; then compound 3.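

In this assay, this saturated ring carbon proves far less forgiving than the ring exchange alone suggested (a 2.1-fold lower number from compound 1 to compound 2 (0.32 log units; beyond the scatter)): 2-methoxyphenyl costs much more against either hydroxylated group (a 110-fold higher number from compound 2 to compound 3 (2.04 log units; beyond the scatter); a 53-fold higher number from compound 1 to compound 3 (1.72 log units; beyond the scatter)). Among these three compounds, the 3-hydroxyphenyl of compound 1 and the 5-hydroxypyridin-2-yl of compound 2 stay fairly close, while the 2-methoxyphenyl of compound 3 stands well apart, with 0 hydrogen-bond donors against 1 in the group it replaces in compound 2. No evidence at hand explains the size of this loss.

Compound 3 changes the oxygen substituent and its place on the ring together, so the compounds shown leave open which change carries the loss. A 3-methoxyphenyl or a 2-hydroxyphenyl group at this carbon would separate the two, and a plain phenyl would show what the hydroxyl itself contributes.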